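A one-carbon extension and its expected effect on lipophilicity

The source may hold more compounds than are shown below. What is called first, only, known or untested is meant among the compounds shown, and "the series" means these compounds.

Compound 1, `CCCCCOC(=O)c1ccc(S(N)(=O)=O)cc1`, gives 2.71 in a physicochemical assay for lipophilicity; a lower number here means a more polar compound, a higher number a more lipophilic compound.
Compound 2, `CCCCCCOC(=O)c1ccc(S(N)(=O)=O)cc1`, gives 3.23 in this assay.
Compound 3, `CNC(=O)c1ccc(S(N)(=O)=O)cc1`, gives -0.31 in this assay.

Compound 4, `CCNC(=O)c1ccc(S(N)(=O)=O)cc1`, has not yet been measured. It differs from compound 3 by methyl in place of hydrogen on a saturated chain carbon bound to an amide-type nitrogen. The same kind of change is already on record between two measured compounds: compound 2 differs from compound 1 by methyl in place of hydrogen on a saturated chain carbon, five bonds along the chain from an oxygen next to a carbonyl group, and that change produced a number 0.52 log units higher from compound 1 to compound 2 (beyond the scatter). The two places are not identical, however. In the measured pair the added methyl sits five bonds along the chain from an oxygen next to a carbonyl group, whereas in the new pair it sits on a saturated chain carbon bound to an amide-type nitrogen, so the earlier step is a guide of the same kind rather than the same step.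

The two cores also differ. Compound 3 differs from compound 1 by methylamino in place of pentyloxy on a carbonyl carbon, and that difference is accompanied by a number 3.02 log units lower from compound 1 to compound 3 (beyond the scatter), leaving compound 3 as the lowest of the three measured values.

Because a number 0.52 log units higher from compound 1 to compound 2 (beyond the scatter) was a modest rise, a rise of similar or slightly smaller size is expected here as well. For compound 4 the estimate means a number 0.46 log units higher from compound 3 to compound 4 (beyond the scatter), which is expected to be a little smaller than a number 0.52 log units higher from compound 1 to compound 2 (beyond the scatter). Compound 4 is therefore expected to come in at 0.15, between -0.15 and 0.5.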

Compound 4, partition coefficient: 0.03
Estimate against measurement, compound 4: 0.12 log units above; low and high end bracket the measured number.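

In this assay the added methyl gives a rise on both cores: the step reads a number 0.34 log units higher from compound 3 to compound 4 (beyond the scatter) on the core of compound 3 and a number 0.52 log units higher from compound 1 to compound 2 (beyond the scatter) on the core of compound 1, and both are modest and in the same direction. The change therefore carries over in direction between these two pairs, and it stays small beside the difference between the two cores, which still reads a number 2.68 log units lower from compound 1 to compound 4 (beyond the scatter) after the extension from methylamino to ethylamino. Among these compounds, with only one pair on each core and the methyl in a different place in each pair, this does not establish a fixed increment for the change across the series, and nothing measured here bears on what sets the size of either step.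

The compounds shown leave open whether the rise continues from ethylamino to propylamino or butylamino, or whether it holds on a chain that ends in an amine or a carboxylic acid. They also leave open how ethoxy would compare with ethylamino on the same carbonyl carbon, a pair that would separate the change of chain length from the change at the atom bound to the carbonyl carbon.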